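Small Substituent Swap on a Xanthine Core: Acid to Ether

A few compounds are considered here, and "the series" means these few. Any claim that something is new, unique, unknown or untested is made for them only; others in the source may bear on it.

Compound 1: `CC(C)CCn1c(=O)c2nc[nH]c2n(CC(C)C)c1=O` — 6240 nM
Compound 2: `CC(=O)OCCn1cnc2c1c(=O)n(C)c(=O)n2C` — 23200 nM
Compound 3: `Cn1cnc2c1c(=O)n(CC(=O)O)c(=O)n2C` — 23500 nM

In an assay on HEK293 cells for binding affinity to adenosine receptor A2b (Homo sapiens), read by radioligand binding (a higher number here means a weaker inhibitor, a lower number a stronger inhibitor), compound 3 gives 23500 nM, the highest of the three numbers. Compound 2 sits within the scatter of it, so the two cannot be told apart; compound 1 gives a clearly lower number, beyond the scatter. Compound 4, `COCn1c(=O)c2c(ncn2C)n(C)c1=O`, is compound 3 with methoxy in place of carboxy on a saturated chain carbon bound to an aromatic nitrogen. Among the measured compounds shown here, no measured pair shows this exact change, so the direction rests only on the three values shown, which all lie in a weak range. The expected step from compound 3 to compound 4 is a modest drop in the number, a 2.0-fold lower number from compound 3 to compound 4 (0.29 log units; within the scatter). Compound 4 is thus estimated at 12000 nM, with a plausible range from 4000 nM to 40000 nM.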

Compound 4, inhibition constant: 14000 nM
Compound 4: middle estimate off by 1.2-fold (0.07 log units), on the low side; measured number inside the range.
By their numbers in this assay, from the lowest: compound 1; then compounds 4, 2 and 3 (each within the scatter of the next).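

On a saturated chain carbon bound to an aromatic nitrogen, methoxy in place of carboxy gives a 1.7-fold lower number from compound 3 to compound 4 (0.22 log units; within the scatter) in this assay, so the two compounds cannot be told apart. At this position, then, losing the carboxy group and its hydrogen-bond donor leaves the number in the same weak range. Nothing measured here bears on the cause of this result.

Still open, as far as these compounds go, is whether an amine or a longer chain at this position would shift the number beyond the scatter. A single pair also cannot show whether this swap behaves the same way on other compounds.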